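Triazole series: anilino group in place of cyclopropylmethyl

This account rests on a few compounds, and the source may have more. Where it says the series, first, only, none or still open, it means among the compounds named here.

Compound 2 `CCCN(CC1CC1)c1nc(-c2ccc(Cl)cc2Cl)n(C)n1` in an assay on CHO cells for binding affinity to corticotropin-releasing factor receptor 1 (Homo sapiens) (a lower number here means a stronger inhibitor, a higher number a weaker inhibitor), gives only a limit, > 10000 nM. Compound 3 `CCCN(c1nc(-c2ccc(Cl)cc2Cl)nn1C)C(C1CC1)C1CC1` likewise gives a limit in this assay, > 10000 nM. Compound 1 `CCCN(c1nc(-c2cc(F)c(Cl)cc2Cl)n(C)n1)C(C1CC1)C1CC1` gives 15 nM in this assay. Two of the three values shown thus sit at the limit of > 10000 nM in this assay, at which 2 of the 3 values shown sit; only compound 1 yields a number. Compound 4 `CCCN(c1nc(-c2ccc(Cl)cc2Cl)n(C)n1)c1ccccc1OC` carries 2-methoxyphenyl in place of cyclopropylmethyl on a nitrogen on an aromatic ring. Within the data shown here, no measured pair isolates this change, so the size of the move in this assay cannot be read off; a gain of some size is the expectation, its extent open since compound 2 itself is unresolved. Compound 4 is estimated at 2000 nM, between 100 nM and 10000 nM. That estimate corresponds to an expected step of an at least 5.0-fold lower number from compound 2 to compound 4 (0.69 log units; beyond the scatter).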

Compound 4, inhibition constant: 3400 nM
Compound 4: the middle estimate sits 1.7-fold (0.23 log units) below what was measured; measured number inside the range.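

In this assay, 2-methoxyphenyl in place of cyclopropylmethyl on this nitrogen gives an at least 2.9-fold lower number from compound 2 to compound 4 (0.46 log units; beyond the scatter). An aromatic ring at this position therefore still leaves a resolved number, and compound 4 reads 3400 nM. The true size of the step stays unresolved because compound 2 gives only a limit: the limit of > 10000 nM in this assay, at which 2 of the 4 values shown sit.

Open, from the compounds shown here alone, is whether the gain belongs to the aromatic ring or to its methoxy group, which a plain phenyl or a 2-chlorophenyl on this nitrogen would separate. Among these compounds, compound 4 and compound 1 differ in more than one place, so no step between them can be read.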